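The compounds below may be only part of what the source reports. "The series", "measured", "known", "first", "only" and "open" are said of these compounds alone.

Among the compounds with values here, in a functional assay on A549 cells (Homo sapiens) for antiproliferative activity, read by MTT assay, with a stated time of 72 h (on this read-out higher numbers stand for weaker inhibition and lower numbers for stronger inhibition), three compounds sharing one core have numbers so far: compound 1 `CC(C)(C)OC(=O)N1CCN(C(=S)Sc2ccc(C(C)(C)C)cc2)CC1` gives 769 nM, compound 2 `CC(C)(C)OC(=O)N1CCN(C(=S)Sc2ccc(F)cc2)CC1` gives 1560 nM, and compound 3 `CC(C)(C)OC(=O)N1CCN(C(=S)Sc2ccc(Cl)cc2)CC1` gives 1070 nM. Compound 3 stands within the scatter of both the others, even though those two are separated by a modest step, a 2.0-fold higher number from compound 1 to compound 2 (0.31 log units; beyond the scatter). The next compound, compound 4 `Cc1cccc(SC(=S)N2CCN(C(=O)OC(C)(C)C)CC2)c1`, brings 3-methylphenyl in place of 4-chlorophenyl on a sulfur. The measured steps that bear on this all exchange one group on an aromatic carbon for another. Two of them, a 1.4-fold higher number from compound 1 to compound 3 (0.14 log units; within the scatter) and a 1.5-fold lower number from compound 2 to compound 3 (0.16 log units; within the scatter), stay within the scatter, and a 2.0-fold higher number from compound 1 to compound 2 (0.31 log units; beyond the scatter) only just passes it. Within the data shown here, no measured compound carries 3-methylphenyl, so the data give no direction. In this assay, no change beyond the scatter is therefore expected. The expected change is a 1.1-fold lower number from compound 3 to compound 4 (0.03 log units; within the scatter), an estimate that carries little weight on its own. Compound 4 is estimated at 1000 nM, with an expected range of 500 nM to 2100 nM.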

Compound 4, half-maximal inhibitory concentration: 914 nM
Estimate against measurement, compound 4: 1.1-fold (0.04 log units) above; measured number inside the range.
By their numbers in this assay, from the lowest: compounds 1, 4, 3 and 2 (each within the scatter of the next, the first and the last beyond it).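

In this assay, replacing the halogen-bearing group on the sulfur with 3-methylphenyl, which holds carbon only, gives a 1.2-fold lower number from compound 3 to compound 4 (0.07 log units; within the scatter) and, from the fluorine-bearing group, a 1.7-fold lower number from compound 2 to compound 4 (0.23 log units; within the scatter). Both steps stay within the scatter, so among these compounds chlorine or fluorine is not needed to keep the number in this range, and this place accepts a different group without a change that can be read. Nothing measured here accounts for this result.

From the compounds shown here alone, all four compounds carry a single small carbon or halogen substituent on the aromatic ring, so what an amine or a carboxylic acid would do there remains open. Equally open, going by these compounds, is whether a longer chain in place of the aromatic ring on the sulfur would keep the number in the same range.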